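A few compounds are considered here, and "the series" means these few. Any claim that something is new, unique, unknown or untested is made for them only; others in the source may bear on it.

Three compounds have been examined in a toxicity assay on NIH3T3 cells (Mus musculus) for cytotoxicity, read by resazurin assay; on this read-out higher numbers stand for an effect only at larger amounts of compound and lower numbers for an effect already at smaller amounts. Compound 1 `O=C(c1ccc(NCc2cncn2Cc2ccc(-c3ccccc3)cc2)cc1-c1ccccc1)N1CCCCC1` reaches only a limit in this assay, reported as > 1000 nM. Compound 2 `COC(=O)c1ccc(NCc2cncn2Cc2ccccc2N)cc1-c1ccccc1` gives 25000 nM in this assay. For compound 3 `Clc1ccc(Cn2cncc2CNc2ccc(-c3nc4ccccc4s3)c(-c3ccccc3)c2)cc1` this assay again reports a limit, > 1000 nM. Compound 1 therefore stands at the limit shared by most of the set, namely (the limit of > 1000 nM in this assay, at which 2 of the 3 values shown sit). Compound 4 `c1ccc(-c2ccc(Cn3cncc3CNc3ccc(-c4noc5ccccc45)c(-c4ccccc4)c3)cc2)cc1` differs from compound 1 by a group of 9 heavy atoms (7 carbon, 1 nitrogen, 1 oxygen; one five-membered aromatic ring with 2 hetero atoms, one six-membered aromatic ring of carbon only) in place of a group of 8 heavy atoms (6 carbon, 1 nitrogen, 1 oxygen; one six-membered non-aromatic ring with 1 hetero atom), on an aromatic carbon. Among the measured compounds shown here, no step between measured compounds is available here, so the change in this assay is expected to stay within the usual scatter, with compound 4 most likely also ending at a limit. Compound 4 is expected to give about 3000 nM, within the range 1000 nM to 10000 nM. The expected step that the limit leaves unreadable from compound 1 to compound 4 is accordingly small.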

Compound 4, half-maximal effective concentration: > 10000 nM
Compound 4 was reported as a limit (the forecaster's own chance of this, stated with the estimate: 60%); middle value at least 3.3-fold (0.52 log units) away from the limit.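

Compound 1 and compound 4 are both reported only as limits, and the step between them cannot be read. The compounds shown leave open whether replacing the (piperidin-1-yl)carbonyl group changes the result in this assay at all.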